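Swapping methoxy for fluoro on a second core

The compounds below may be only part of what the source reports. "The series", "measured", "known", "first", "only" and "open" are said of these compounds alone.

Compound 1 `CCN1CCN(c2ccc(S(=O)(=O)Oc3cccc(OC)c3)cc2)C1=O` gives 7000 nM in a functional assay on M21 cells (Homo sapiens) for antiproliferative activity, read by sulforhodamine B assay, with a stated time of 48 h; a higher number here means a weaker inhibitor, a lower number a stronger inhibitor.
Compound 2 `CCN1CCN(c2ccc(S(=O)(=O)Oc3cccc(F)c3)cc2)C1=O` gives 11000 nM in this assay.
Compound 3 `CCCN1CCN(c2ccc(S(=O)(=O)Oc3cccc(OC)c3)cc2)C1=O` gives 10000 nM in this assay.

Compound 4 `CCCN1CCN(c2ccc(S(=O)(=O)Oc3cccc(F)c3)cc2)C1=O` has not yet been measured. It is related to compound 3 by fluoro in place of methoxy on an aromatic carbon, and the same change, (fluoro in place of methoxy on an aromatic carbon), has already been measured once: it gave a 1.6-fold higher number from compound 1 to compound 2 (0.20 log units; within the scatter). The two cores on which the change is made differ by methyl in place of hydrogen on a saturated chain carbon, two bonds along the chain from an amide-type nitrogen in a ring. In both cases the change sits on an aromatic carbon of a six-membered aromatic ring of carbon only, meta to a large group, so it counts as the same change. The step from compound 3 to compound 4 is therefore expected to be about a 1.6-fold higher number from compound 3 to compound 4 (0.20 log units; within the scatter), because a 1.6-fold higher number from compound 1 to compound 2 (0.20 log units; within the scatter) was seen on the first core. Compound 4 is estimated at 16000 nM, with a likely range from 7000 nM to 35000 nM.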

Compound 4, half-maximal inhibitory concentration: 12000 nM
Compound 4: the middle estimate sits 1.3-fold (0.12 log units) above what was measured; the range from low to high includes it.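

In this assay, fluoro in place of methoxy gives a 1.2-fold higher number from compound 3 to compound 4 (0.08 log units; within the scatter), and the two cores agree on this change within the scatter: the same change on two cores in this assay, a 1.6-fold higher number (0.20 log units; within the scatter) from compound 1 to compound 2 and a 1.2-fold higher number (0.08 log units; within the scatter) from compound 3 to compound 4, 1.3-fold (0.12 log units) apart, within the scatter of two such steps. Adding the methyl to the saturated chain gives a 1.1-fold higher number from compound 2 to compound 4 (0.04 log units; within the scatter), and this change also agrees across the two cores: the same change on two cores in this assay, a 1.4-fold higher number (0.15 log units; within the scatter) from compound 1 to compound 3 and a 1.1-fold higher number (0.04 log units; within the scatter) from compound 2 to compound 4, 1.3-fold (0.12 log units) apart, within the scatter of two such steps. All of these steps lie within the scatter, which shows that neither change has a readable effect on these cores, but not that a change with a clear effect would carry from one core to another in the same way.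

The compounds shown leave open what an amine or a carboxylic acid in place of the fluoro would do. They also leave open the effect of a longer chain on the amide-type nitrogen.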